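The compounds below may be only part of what the source reports. "The series", "measured", "known", "first", "only" and "open" are said of these compounds alone.

Measured so far:
compound 1 `COC(=O)c1cc(N)c(Nc2ccc(C#N)cc2)cc1Oc1c(C)cc(/C=C/C#N)cc1C`: > 22800 nM in an ADME assay on TZM cells (Homo sapiens) for cytotoxicity, read by XTT assay, with a stated time of 4 days; a higher number here means that more compound is tolerated, a lower number that less compound is tolerated
compound 2 `Cc1cc(CCC#N)cc(C)c1Oc1cc(Nc2ccc(C#N)cc2)c(N)cc1CO`: > 23800 nM in this assay

Both readings are limits of this assay rather than numbers. Compound 1 sits at the limit of > 22800 nM in this assay, at which 1 of the 2 values shown sits. Compound 2 sits at the limit of > 23800 nM in this assay, at which 1 of the 2 values shown sits. Going by the values given here, compound 2 therefore stands where the only other measured compound stands: at the edge of what this assay can report, with no numbered value anywhere to order it against. Nothing here separates the two compounds, and no pattern can be drawn from them.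

Compound 3 `COC(=O)c1cc(N)c(Nc2ccc(C#N)cc2)cc1Oc1c(C)cc(CCC#N)cc1C` differs from compound 2 by methoxycarbonyl in place of hydroxymethyl on an aromatic carbon. Among the compounds with values here, since no step between measured compounds is available, the expectation for this assay rests only on the two limits: the change is expected to produce no step beyond the scatter, with compound 3 most likely reported again as a limit rather than a number. Compound 3 is expected to give 25000 nM in this assay, with a range from 10000 nM to 60000 nM. The estimated step that the limit leaves unreadable from compound 2 to compound 3 is thus expected to be essentially flat.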

Compound 3, half-maximal cytotoxic concentration in the TZM assay: > 22700 nM
Compound 3: no number, only a limit (the forecaster's own chance of this, stated with the estimate: 80%); the middle value does not contradict the limit.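

Going by these compounds alone, in the TZM assay, compound 1, compound 2 and compound 3 all read as limits, not numbers, so no step between them can be read. In a physicochemical assay for lipophilicity, at pH 7.4 (a lower number here means a more polar compound, a higher number a more lipophilic compound), compound 2 gives 3.68 and compound 3 gives 4.15, which is a number 0.47 log units higher from compound 2 to compound 3 (beyond the scatter). The compounds shown leave open whether this difference has any counterpart in the TZM assay, where no numbered value exists.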